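Lengthening the Chain Toward the Phenyl Group

A few compounds are considered here, and "the series" means these few. Any claim that something is new, unique, unknown or untested is made for them only; others in the source may bear on it.

Of the compounds shown here, two sharing one core have been measured in an assay on PMNL cells for inhibition of Polyunsaturated fatty acid 5-lipoxygenase (Homo sapiens), read by HPLC, with stated times of 5 min and 15 min; a higher number here means a weaker inhibitor, a lower number a stronger inhibitor. Compound 1 `COc1cc(/C=C/C(=O)OCCCc2ccccc2)cc(OC)c1O` gives 340 nM. Compound 2 `COc1cc(/C=C/COCc2ccccc2)cc(OC)c1O` gives 1100 nM, the higher of the two numbers and therefore the weaker inhibitor of the pair; the gap to compound 1 lies beyond the usual scatter. For the measured compounds named here, the two differ from each other in more than one place, so no single structural step connects them, and their values say only where each stands.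

Compound 3 `COc1cc(/C=C/COCCCc2ccccc2)cc(OC)c1O` is not yet measured. It arises from compound 2 by one change: phenethyl in place of phenyl on a saturated chain carbon bound to an oxygen on a saturated carbon. Nothing measured here isolates this kind of change, so its effect can only be anticipated. The available measurements give little ground to expect a large shift in either direction; a modest fall in the number, toward stronger inhibition, seems about as likely as no change at all, so the expected step from compound 2 to compound 3 is a 1.8-fold lower number from compound 2 to compound 3 (0.26 log units; within the scatter), a move near the edge of the scatter. Compound 3 is accordingly estimated at 600 nM, with a plausible range from 250 nM to 1500 nM.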

Compound 3, half-maximal inhibitory concentration: 560 nM
Compound 3: middle estimate off by 1.1-fold (0.03 log units), on the high side, within the range that was stated.
By their numbers in this assay, from the lowest: compounds 1, 3 and 2 (each within the scatter of the next, the first and the last beyond it).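

In this assay, for the compounds shown here, the swap of phenyl for phenethyl on a saturated chain carbon bound to an oxygen on a saturated carbon is the first change at this position that can be read on its own, and it gives a 2.0-fold lower number from compound 2 to compound 3 (0.29 log units; within the scatter). The two compounds therefore cannot be told apart by this measurement: the position holds the larger phenethyl group with no loss of inhibition that stands out from the scatter, and no real gain can be claimed either. Nothing measured here says why the step has this size.

Going by these compounds, a single step also cannot show how far this tolerance extends, so it remains open whether a longer chain, such as phenylpropyl or phenylbutyl, would give a number clearly different from those of compound 2 and compound 3. On these data alone, it is equally open how this position would respond if the phenyl ring at the end of the chain gave way to something of a different kind, such as an amine or a carboxylic acid.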